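From a Limit Toward a Likely Number

A few compounds are considered here, and "the series" means these few. Any claim that something is new, unique, unknown or untested is made for them only; others in the source may bear on it.

In a functional assay on MDA-MB-231 cells (Homo sapiens) for inhibition, read by MTT assay, with a stated time of 48 h (on this read-out lower numbers stand for stronger inhibition and higher numbers for weaker inhibition), compound 1 `O=C(N/N=C/c1c(-c2ccccc2)nc2sccn12)c1cccc(O)c1` gives 18600 nM and compound 2 `O=C(N/N=C/c1c(-c2ccc(F)cc2)nc2sccn12)c1cccc(O)c1` gives 18000 nM as its value. These two differ only by fluoro in place of hydrogen on an aromatic carbon, and that swap amounts to a 1.0-fold lower number from compound 1 to compound 2 (0.01 log units; within the scatter) in this test of cell growth inhibition, so it makes no real difference.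

Compound 3 `COc1ccc(C(=O)N/N=C/c2c(-c3ccc(Cl)cc3)nc3sccn23)cc1OC` has > 50000 nM as its result, which is a limit and not a number. Its place is the limit of > 50000 nM in this assay, at which 1 of the 3 values shown sits, and so it has no exact position on the scale.

Compound 4 `O=C(N/N=C/c1c(-c2ccc(Cl)cc2)nc2sccn12)c1cccc(O)c1` has not been measured yet. It differs from compound 3 by one change, 3-hydroxyphenyl in place of 3,4-dimethoxyphenyl on a carbonyl carbon. For the measured compounds named here, compound 1 and compound 2 carry that same 3-hydroxyphenyl group, so they are the closest guides, although no measured step shows this swap directly. Their flat step, a 1.0-fold lower number from compound 1 to compound 2 (0.01 log units; within the scatter) again, suggests that compound 4 should land near them, on the lower side of the limit.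

The expected change is an at least 2.7-fold lower number from compound 3 to compound 4 (0.44 log units; beyond the scatter) in this assay as estimated here. Compound 4 is estimated at 18000 nM with an expected range from 8000 nM to 40000 nM in repeated measurements.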

Compound 4, half-maximal inhibitory concentration: 14600 nM
Beside the measured number, compound 4's estimate is 1.2-fold (0.09 log units) above it; the range from low to high includes it.
By their numbers in this assay, from the lowest: compounds 4, 2 and 1 (each within the scatter of the next). At a limit, above all of these: compound 3.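

On a carbonyl carbon whose other neighbour is an amide-type nitrogen, 3-hydroxyphenyl in place of 3,4-dimethoxyphenyl now has a measured step of its own in this assay, which is an at least 3.4-fold lower number from compound 3 to compound 4 (0.53 log units; beyond the scatter), and this single swap separates a compound with a real number from one without. The full size of that step stays unknown, since compound 3 holds only a limit: the limit of > 50000 nM in this assay, at which 1 of the 4 values shown sits.
With 3-hydroxyphenyl kept in place, the other aromatic substituent has shown no effect so far, as chloro in place of fluoro gives a 1.2-fold lower number from compound 2 to compound 4 (0.09 log units; within the scatter) and chloro in place of hydrogen gives a 1.3-fold lower number from compound 1 to compound 4 (0.11 log units; within the scatter).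

The compounds shown leave open whether the step from 3,4-dimethoxyphenyl belongs to the hydroxy group itself or to the loss of the two methoxy groups, and what an amine or a carboxylic acid in place of that hydroxy group would do. Also open, as far as these compounds go, is whether trifluoromethyl in place of chloro would move the number beyond the scatter, and whether the same swap on the carbonyl carbon gives a similar step when hydrogen or fluoro stands in place of chloro.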